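Aryl swap on the five-membered ring: compound 2 to compound 3

A few compounds are considered here, and "the series" means these few. Any claim that something is new, unique, unknown or untested is made for them only; others in the source may bear on it.

Compound 1 `Nc1ncnn2c([C@@H]3O[C@H](CO)[C@@H](O)[C@H]3O)cc(C#Cc3ccc(F)cc3)c12` carries a 2-(4-fluorophenyl)ethynyl group on the shared core. In a functional assay on K562 cells (Homo sapiens) for antiproliferative activity, with a stated time of 72 h (on this read-out lower numbers stand for stronger inhibition and higher numbers for weaker inhibition), compound 1 gives only a limit, > 100000 nM, not a number. Compound 2 `Nc1ncnn2c([C@@H]3O[C@H](CO)[C@@H](O)[C@H]3O)cc(-c3ccc(Cl)cc3)c12` replaces that group with 4-chlorophenyl, and in this assay compound 2 gives 47800 nM. The step is an at least 2.0-fold lower number from compound 1 to compound 2 (0.32 log units; beyond the scatter). Among the compounds with values here, compound 2 therefore holds the only number; the other value is the limit (the limit of > 100000 nM in this assay, at which 1 of the 2 values shown sits).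

Compound 3 `Cc1ccccc1-c1cc([C@@H]2O[C@H](CO)[C@@H](O)[C@H]2O)n2ncnc(N)c12` differs from compound 2 by 2-methylphenyl in place of 4-chlorophenyl on an aromatic carbon. Within the data shown here, the one measured step concerns the same position but exchanges a whole ethynyl-linked aryl for a directly attached aryl, so it does not speak directly to a change of substituent on a directly attached aryl. Among the measured compounds shown here, no measured step bears on the chlorine-to-methyl exchange itself; with the aryl kept directly on the ring, a step within the scatter is expected in this assay. Compound 3 is estimated at 60000 nM, range 20000 nM to 150000 nM. The expected step is a 1.3-fold higher number from compound 2 to compound 3 (0.10 log units; within the scatter).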

Compound 3, half-maximal inhibitory concentration: > 100000 nM
Compound 3 ended at the assay's limit; the forecaster's own chance of this, stated with the estimate: 30%; at least 1.6-fold (0.22 log units) between middle value and limit.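

In this assay, 2-methylphenyl in place of 4-chlorophenyl on this aromatic carbon gives an at least 2.0-fold higher number from compound 2 to compound 3 (0.32 log units; beyond the scatter), so a directly attached aryl is not enough by itself, and the substitution on that aryl matters at this position. Compound 3 gives only a limit, > 100000 nM, not a number. The step between compound 1 and compound 3 cannot be read, as both values are limits, and compound 2 remains the only compound with a number, leaving little measured range for comparing groups at this position: the limit of > 100000 nM in this assay, at which 2 of the 3 values shown sit.

The step from 4-chlorophenyl to 2-methylphenyl changes both the substituent and its place on the aryl, so the compounds shown do not separate the loss of chlorine from the move to the 2-position; 4-methylphenyl or 2-chlorophenyl would be the direct links between them. Also open, on these data alone, is whether any group on this carbon gives a number well below that of compound 2, for instance an aryl bearing an amine or a carboxylic acid, or an unsubstituted phenyl.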